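Styryl quinoline oxadiazoles: tolerability on liver cells

A few compounds are considered here, and "the series" means these few. Any claim that something is new, unique, unknown or untested is made for them only; others in the source may bear on it.

Compound 1 `COc1ccc(-c2nc(/C=C/c3cc4ccccc4nc3OC)no2)cc1` and compound 2 `COc1nc2ccccc2cc1/C=C/c1noc(-c2ccccc2C)n1` share one core and differ only in the aryl group carried on the five-membered ring. In an ADME assay on HepG2 cells (Homo sapiens) for cytotoxicity, read by sulforhodamine B assay, with a stated time of 48 h (a lower number here means that less compound is tolerated, a higher number that more compound is tolerated), compound 1 reaches only the limit of the assay, > 220000 nM, and not a number. In this assay compound 2 likewise reaches only the limit, > 230000 nM, and not a number. The step that the two limits leave unreadable from compound 1 to compound 2 is therefore not readable; the two sit at the limit of > 220000 nM in this assay, at which 1 of the 2 values shown sits, and at the limit of > 230000 nM in this assay, at which 1 of the 2 values shown sits.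

Compound 3 `COc1nc2ccccc2cc1/C=C/c1noc(-c2cccnc2)n1` is the next member, not yet measured, and its change from compound 2 is pyridin-3-yl in place of 2-methylphenyl on an aromatic carbon. For the measured compounds named here, no measured step gives a readable size, so the only guide is that compound 2 is tolerated up to the limit. Compound 3 is expected to behave the same way, with an estimate of 250000 nM and a range from 100000 nM to 600000 nM. The expected step that the limit leaves unreadable from compound 2 to compound 3 is therefore none beyond the scatter, most likely again reported as a limit.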

Compound 3, half-maximal cytotoxic concentration: > 240000 nM
Compound 3: a limit, no number (the forecaster's own chance of this, stated with the estimate: 80%); the middle value lies beyond the limit too.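

In this assay compound 3 gives > 240000 nM, a limit and not a number. For the compounds shown here, with compound 1 and compound 2 also at limits, no step among the three can be read. Going by these compounds, whether these aryl groups differ at all in tolerated concentration stays open.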